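This account rests on a few compounds, and the source may have more. Where it says the series, first, only, none or still open, it means among the compounds named here.

In a physicochemical assay for solubility (on this read-out lower numbers stand for lower solubility and higher numbers for higher solubility), compound 1 `CNC(=O)c1cc(C(=O)NC2CC2)cn(Cc2ccc(OC)cc2)c1=O` gives >= 143 ug/mL, which is a limit and not a number. Compound 2 `CNC(=O)c1cc(C(=O)NC2CC2)cn(Cc2cccc3c2CCN3)c1=O` also gives only a limit, >= 184 ug/mL. In compound 3 `CNC(=O)c1cc(C(=O)NC2CC2)cn(Cc2ccc3nc[nH]c3c2)c1=O`, 1H-benzimidazol-6-yl replaces 2,3-dihydro-1H-indol-4-yl on a saturated chain carbon bound to an aromatic nitrogen: 1H-benzimidazol-6-yl in place of 2,3-dihydro-1H-indol-4-yl on a saturated chain carbon bound to an aromatic nitrogen. For the measured compounds named here, the one measured step at this place is a step that the two limits leave unreadable from compound 1 to compound 2, so it offers no size to carry over. In this assay, no step beyond the scatter is therefore expected, in either direction. The estimated step is an at least 1.0-fold lower number from compound 2 to compound 3 (0.03 log units; that floor lies within the scatter). For compound 3, the expected value is 170 ug/mL, with an estimated range of 70 ug/mL to 300 ug/mL.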

Compound 3, solubility: >= 163 ug/mL
Compound 3: no number, only a limit (the forecaster's own chance of this, stated with the estimate: 65%); the middle value does not contradict the limit.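

Compound 3 gives >= 163 ug/mL in this assay, which is a limit and not a number. Compound 1 and compound 2 also give only limits, so no step among these compounds can be read. As far as these compounds go, what stays open is whether exchanging these groups changes the read-out at all.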